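Aryl halogen swap on the piperazine amide series

This account rests on a few compounds, and the source may have more. Where it says the series, first, only, none or still open, it means among the compounds named here.

Measured compounds:
compound 1 `CC(C)C[C@H](N)c1cc(Cl)ccc1N1CCN(C(=O)C(C)Cc2ccc(Cl)cc2)CC1` — 67 nM
compound 2 `COc1ccc(OCC(=O)N2CCN(c3ccc(C(F)(F)F)cc3[C@@H](N)CC(C)C)CC2)cc1` — 3800 nM

In an assay on HEK293 cells for displacement of a labelled ligand from Melanocortin receptor 4 (Homo sapiens) (on this read-out higher numbers stand for weaker inhibition and lower numbers for stronger inhibition), compound 1 gives 67 nM, the lowest of the two numbers; compound 2 gives 3800 nM, a gap well beyond the scatter, with several parts of the structure differing at once.

Compound 3 `CC(C)C[C@H](N)c1cc(F)ccc1N1CCN(C(=O)C(C)Cc2ccc(Cl)cc2)CC1` is the next compound to be measured. It differs from compound 1 only in fluoro in place of chloro on an aromatic carbon. Within the data shown here, no pair of measured compounds isolates this change, so the size of the step is open. The expectation for compound 3 in this assay is 120 nM (range 40 nM to 400 nM), a step of a 1.8-fold higher number from compound 1 to compound 3 (0.25 log units; within the scatter), small, toward a slightly higher number, and possibly within the scatter.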

Compound 3, inhibition constant: 390 nM
Beside the measured number, compound 3's estimate is 3.3-fold (0.51 log units) below it; measured number inside the range.
By their numbers in this assay, from the lowest: compound 1; then compound 3; then compound 2.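

In this assay, fluoro in place of chloro on the aromatic carbon meta to the 1-amino-3-methylbutyl group gives a 5.8-fold higher number from compound 1 to compound 3 (0.76 log units; beyond the scatter), beyond the scatter. Among these compounds, this is the first comparison that isolates a single place, and it shows that the number at this position depends on which halogen sits there, with chloro giving the lower number of the two. Nothing at hand accounts for the size of this step.

Still open, on these data alone, is whether bromo or a nitrile at this position would give a number lower than chloro. Also open, as far as these compounds go, is whether the step keeps its size when the amide side of compound 1 is replaced by the methoxyphenoxyacetyl group of compound 2.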